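The source may report more compounds than this note shows. Statements on the series, on what has been measured and on what is new or still open speak of the compounds shown alone.

Values in an ADME assay on MDBK cells (Bos taurus) for cytotoxicity, read by MTT assay, with a stated time of 96 h; a higher number here means that more compound is tolerated, a lower number that less compound is tolerated:
compound 1, `CC(=O)c1ccc2c(c1)nc(-c1ccccc1)n2C1CCCCC1`, gives a limit, > 100000 nM.
compound 2, `COc1ccc(-c2nc3cc(C(C)=O)ccc3n2C2CCCCC2)cc1`, gives a limit, > 100000 nM.
compound 3, `COc1ccc(-c2nc3cc(/C(C)=N/NC(N)=S)ccc3n2C2CCCCC2)cc1`, gives 32000 nM.

The change from compound 1 to compound 2 is methoxy in place of hydrogen on an aromatic carbon; with both values at a limit, the step that the two limits leave unreadable from compound 1 to compound 2 cannot be read. For the measured compounds named here, the step of an at least 3.1-fold lower number from compound 2 to compound 3 (0.49 log units; beyond the scatter) is the one readable step, and compound 3 is the only compound with a number, since (the limit of > 100000 nM in this assay, at which 2 of the 3 values shown sit).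

Compound 4, `COc1ccc(-c2nc3cc(/C(C)=N/NC(N)=S)ccc3n2C2CCCCC2)c(OC)c1`, is not yet measured. It differs from compound 3 by methoxy in place of hydrogen on an aromatic carbon, the same kind of change as that from compound 1 to compound 2, but here the methoxy enters ortho to a large group and meta to a methoxy group, whereas before it entered para to a large group. The difference between the cores of compound 1 and compound 3 is not broken down here.

Because the earlier step that the two limits leave unreadable from compound 1 to compound 2 is unreadable, the expectation for compound 4 rests on compound 3 alone, giving 32000 nM, and the step is expected to stay small, a 1.1-fold lower number from compound 3 to compound 4 (0.03 log units; within the scatter). Compound 4 is estimated at 30000 nM, expected to lie between 10000 nM and 100000 nM.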

Compound 4, half-maximal cytotoxic concentration: > 100000 nM
Compound 4: no number, only a limit; the forecaster's own chance of this, stated with the estimate: 20%; at least 3.3-fold (0.52 log units) between middle value and limit.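

In this assay, methoxy in place of hydrogen gives an at least 3.1-fold higher number from compound 3 to compound 4 (0.49 log units; beyond the scatter), the change that turns the 4-methoxyphenyl of compound 3 into the 2,4-dimethoxyphenyl of compound 4. Going by these compounds, compound 4 gives > 100000 nM, which is a limit and not a number, and the full size of the step stays unknown. The same kind of change on the core of compound 1 gives a step that cannot be read, and whether the change carries from one core to another stays unanswered because of where the values sit: the limit of > 100000 nM in this assay, at which 3 of the 4 values shown sit.

Open, on these data alone, is whether ethoxy or a chlorine atom in the place of the new methoxy would give a step of the same kind. Also open, as far as these compounds go, is whether an amine or a carboxylic acid there would.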